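Swapping the Cyclopropylcarbonyl for a Methyl-Oxazolyl Group

The source may hold more compounds than are shown below. What is called first, only, known or untested is meant among the compounds shown, and "the series" means these compounds.

Three compounds sharing one core were examined in an assay on membranes from CHO cells for displacement of a labelled ligand from adenosine receptor A1 (Homo sapiens), read by scintillation counting, with a stated time of 60 min, tested at 1 uM; on this read-out lower numbers stand for less inhibition and higher numbers for more inhibition at the one concentration tested (going by the name of the read-out). Compound 1 `CC1=C(C(=O)OC(C)(C)C)C(c2cccs2)NC(=O)N1` gives 26%, compound 2 `CC1=C(C(=O)C2CC2)C(c2ccco2)NC(=O)N1` gives 2%, and compound 3 `CC1=C(C(=O)C2CC2)C(c2cccs2)NC(=O)N1` gives 1%. Compound 3 therefore holds the lowest of the three numbers, though its gap to compound 2 is within the scatter, so the two cannot be ordered; only compound 1 sits clearly apart, as the step of a number 25 percentage points lower from compound 1 to compound 3 (beyond the scatter) shows. The other measured step, a number 1 percentage points lower from compound 2 to compound 3 (within the scatter), concerns the saturated ring carbon and is within the scatter.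

Compound 4 `CC1=C(c2ncc(C)o2)C(c2cccs2)NC(=O)N1` is the next member. Relative to compound 3 it differs as follows: 5-methyl-1,3-oxazol-2-yl in place of cyclopropylcarbonyl on a double-bonded ring carbon. The step from compound 1 to compound 3 is the one that bears on this change, since it too altered the group on the double-bonded ring carbon, and it was modest and beyond the scatter. Among the compounds with values here, the new group, however, has no measured counterpart here; the carbonyl itself disappears and an aromatic ring enters, so the direction is open. Compound 4 is expected to stay near compound 3, with an estimated step of a number 7 percentage points higher from compound 3 to compound 4 (within the scatter) in this assay. The estimated value for compound 4 is 8%, with a range from 0% to 30%.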

Compound 4, a percentage reported as inhibition, at one concentration (the size of the read-out at that concentration, not a potency): 21%
For compound 4 the middle estimate is 13 percentage points below the measured one; low and high end bracket the measured number.
By their numbers in this assay, from the lowest: compounds 3 and 2 (each within the scatter of the next); then compounds 4 and 1 (each within the scatter of the next).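

In this assay, a number 20 percentage points higher from compound 3 to compound 4 (beyond the scatter) shows that the number at this double-bonded ring carbon does not depend on keeping a carbonyl there, since the 5-methyl-1,3-oxazol-2-yl group carries none and still stands clear of cyclopropylcarbonyl. Compound 4 at 21% and compound 1 at 26% lie within the scatter of each other, so an aromatic ring and a tert-butoxy group on a carbonyl carbon both sit apart from the low numbers of the two cyclopropylcarbonyl compounds. No measurement is available that would account for this rise in inhibition.

The compounds shown leave open whether the rise belongs to the oxazole ring itself or to its methyl group, and whether an unsubstituted oxazol-2-yl, a phenyl ring or a simple amide on the same carbon would give a similar number. They also leave open whether the exchange of furan-2-yl for thiophen-2-yl, which stayed within the scatter alongside cyclopropylcarbonyl, would stay as small alongside the 5-methyl-1,3-oxazol-2-yl group.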